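A few compounds are considered here, and "the series" means these few. Any claim that something is new, unique, unknown or untested is made for them only; others in the source may bear on it.

Among the measured compounds shown here, in a functional assay on the whole organism (brain) with Mus musculus as the target (on this read-out lower numbers stand for an effect already at smaller amounts and higher numbers for an effect only at larger amounts of compound), compound 2 `Brc1ccc(OCCc2c[nH]cn2)cc1` gives 2.9 mg/kg, the only actual number so far. Compound 1 `COC(=O)c1ccc(OCCc2c[nH]cn2)cc1` gives > 3 mg/kg, which is a limit of the assay and not a number. The next compound to be tested, compound 3 `FC(F)(F)c1ccc(OCCc2c[nH]cn2)cc1`, carries trifluoromethyl in place of bromo on an aromatic carbon. For the measured compounds named here, one measured step bears on this change, since it also exchanges a group on an aromatic carbon: an at least 1.0-fold lower number from compound 1 to compound 2 (0.01 log units; that floor lies within the scatter). That step gives only a floor, and the floor lies within the scatter, so it sets no size for the new exchange. No change beyond the scatter is therefore expected in this assay. The expected step is a 1.2-fold lower number from compound 2 to compound 3 (0.06 log units; within the scatter). The estimate for compound 3 is 2.5 mg/kg, with an expected range of 1 mg/kg to 6 mg/kg.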

Compound 3, dose for half-maximal effect: > 10 mg/kg
Compound 3: no number, only a limit; the forecaster's own chance of this, stated with the estimate: 25%; middle value at least 4.0-fold (0.60 log units) away from the limit.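

At the aromatic carbon para to a group of 8 heavy atoms, the exchange of bromo for trifluoromethyl does register in this assay: it gives an at least 3.4-fold higher number from compound 2 to compound 3 (0.53 log units; beyond the scatter). Among the compounds shown here, the earlier step between compound 1 and compound 2 offered only a floor within the scatter, so this is the first sign that the read-out responds to what sits at this position. The size of the new step remains a floor because compound 3 stands at a limit and not at a number: the limit of > 10 mg/kg in this assay, at which 1 of the 3 values shown sits.

The step between compound 1 and compound 3 cannot be read, as both values are limits. Still open, as far as these compounds go, are how far compound 3 really lies from compound 2 and how this position would respond to an amine, a carboxylic acid or a chlorine atom in place of bromo.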